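The source may hold more compounds than are shown below. What is called first, only, known or untested is meant among the compounds shown, and "the series" means these compounds.

Compound 1 has the structure `O=C(N/N=C/c1c(-c2cc3ccccc3oc2=O)[nH]c2ccccc12)c1ccccc1Cl`, compound 2 the structure `O=C(N/N=C/c1c(-c2cc3ccccc3oc2=O)[nH]c2ccccc12)c1ccc(Cl)cc1F` and compound 3 the structure `O=C(N/N=C/c1c(-c2cc3ccc(Br)cc3oc2=O)[nH]c2ccccc12)c1ccccc1Cl`. In a functional assay on MCF7 cells (Homo sapiens) for inhibition, read by MTT assay, with a stated time of 48 h (on this read-out lower numbers stand for stronger inhibition and higher numbers for weaker inhibition), compound 1 gives 164000 nM. Compound 2 reaches only a limit of the assay, > 200000 nM. Compound 3 likewise stands in this assay only at a limit of the assay, > 192000 nM, so its place among the numbers shown is known only as a floor (the limit of > 192000 nM in this assay, at which 1 of the 3 values shown sits). The unmeasured compound 4 has the structure `O=C(N/N=C/c1c(-c2cc3ccc(Br)cc3oc2=O)[nH]c2ccccc12)c1ccc(Cl)cc1F` and differs from compound 3 in one place: 4-chloro-2-fluorophenyl in place of 2-chlorophenyl on a carbonyl carbon. The same exchange has been seen once, as an at least 1.2-fold higher number from compound 1 to compound 2 (0.08 log units; that floor lies within the scatter), where the second compound ended on a limit (the limit of > 200000 nM in this assay, at which 1 of the 3 values shown sits). Among the compounds with values here, the other measured step, an at least 1.1-fold higher number from compound 1 to compound 3 (0.06 log units; that floor lies within the scatter), is the one by which compound 3 itself came to stand at its limit. Within the data shown here, neither step shows a movement beyond the scatter, and the only observation of this exchange ends at a floor. The step in this assay is therefore expected to be a step that the limit leaves unreadable from compound 3 to compound 4, with compound 4 most probably reported again at or past the same limit. The value of compound 4 in this assay is estimated as 300000 nM, within a range from 150000 nM to 1000000 nM.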

Compound 4, half-maximal inhibitory concentration: > 200000 nM
Compound 4: a limit, no number; the forecaster's own chance of this, stated with the estimate: 85%; the middle value is on the limit's open side.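

Compound 4 stands at a limit of this assay, as do compound 2 and compound 3, so neither the step from compound 3 to compound 4 nor the step from compound 2 to compound 4 can be read. The compounds shown leave open where these three truly lie relative to compound 1 and to one another.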